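This account rests on a few compounds, and the source may have more. Where it says the series, first, only, none or still open, it means among the compounds named here.

Compound 1 `CN1CCC(C(=O)N2Cc3c(NC(=O)c4ccc5ccccc5c4)n[nH]c3C2(C)C)CC1` is a pair-member in a small set of amides built on a shared core. In a physicochemical assay for solubility, at pH 7 (on this read-out lower numbers stand for lower solubility and higher numbers for higher solubility), compound 1 gives 219000 nM. Among the measured compounds shown here, its only companion with a number, compound 2 `CC(C)(C)C(=O)N1Cc2c(NC(=O)c3ccc(F)cc3)n[nH]c2C1(C)C`, gives in this assay a value of 235000 nM; the two values lie within the scatter of each other, so neither stands apart.

Compound 3 `CN1CCC(C(=O)N2Cc3c(NC(=O)c4cccc(F)c4)n[nH]c3C2(C)C)CC1` has not yet been measured in this assay. It differs from compound 1 in one place: 3-fluorophenyl in place of naphthalen-2-yl on a carbonyl carbon. For the measured compounds named here, no step between two measured compounds matches this change, so nothing in the present data fixes its size. Compound 2, which also carries a fluorophenyl group on the carbonyl carbon, gives 235000 nM in this assay, which suggests the step of a 1.4-fold higher number from compound 1 to compound 3 (0.14 log units; within the scatter) is expected to be small, if anything upward. Compound 3 is estimated to give 300000 nM in this assay, in the range 150000 nM to 600000 nM.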

Compound 3, solubility: > 225000 nM
Compound 3 ended at the assay's limit (the forecaster's own chance of this, stated with the estimate: 5%); the middle value does not contradict the limit.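

With compound 3, the position on the carbonyl carbon now has its first one-place comparison, and the swap of naphthalen-2-yl for 3-fluorophenyl gives an at least 1.0-fold higher number from compound 1 to compound 3 (0.01 log units; that floor lies within the scatter). In this assay, compound 3 gives > 225000 nM, which is a limit of the assay and not a number. The change therefore shows no sign of a drop, yet its full size cannot be read because the read-out stops at the limit: the limit of > 225000 nM in this assay, at which 1 of the 3 values shown sits.

Still open, going by these compounds, is how far compound 3 really lies past that limit, and whether any step here belongs to the loss of the second aromatic ring or to the fluorine. Also open, on these data alone, is how a plain phenyl group, or a phenyl ring carrying an amine or a carboxylic acid, would read at this place.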